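Adding a Second Bromine to a Catechol Core

A few compounds are considered here, and "the series" means these few. Any claim that something is new, unique, unknown or untested is made for them only; others in the source may bear on it.

Measured compounds:
compound 1 `O=C(c1ccccc1)c1cc(O)c(O)cc1Br`, in a functional assay on HUVEC cells (Homo sapiens) (a higher number here means that more compound is needed for the effect, a lower number that less compound is needed), compound 1 gives 11500 nM
compound 2 `Oc1cc(Br)c(Cc2ccccc2)cc1O`, in this assay compound 2 gives 12200 nM
compound 3 `O=C(c1ccccc1)c1cc(O)c(O)c(Br)c1Br`, in this assay compound 3 gives 800 nM

Compound 3 differs from compound 1 in one place: bromo in place of hydrogen on an aromatic carbon. Going by the values given here, this single exchange gave a 14-fold lower number from compound 1 to compound 3 (1.16 log units; beyond the scatter), the only step among the three measured compounds that clearly stands out. Compound 2 and compound 1, by contrast, give numbers that lie within the usual scatter of one another, so nothing can be said about which of the two needs more or less compound; the difference between their two cores is not broken down here.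

Compound 4 `Oc1cc(Cc2ccccc2)c(Br)c(Br)c1O` has not yet been measured in this assay. It is related to compound 2 exactly as compound 3 is to compound 1: bromo in place of hydrogen on an aromatic carbon. The surroundings of the new bromine are nearly alike in both pairs; the only difference is that in compound 4 the bromine is meta to a group of 7 heavy atoms, whereas in compound 3 it is meta to a group of 8 heavy atoms. The change is therefore the same kind of change, not the very same one.

Among the compounds with values here, with only one earlier example to lean on, the expectation is that compound 4 will show a step of about a 10-fold lower number from compound 2 to compound 4 (1.01 log units; beyond the scatter), because the same kind of exchange gave a 14-fold lower number from compound 1 to compound 3 (1.16 log units; beyond the scatter). On that basis compound 4 is estimated at 1200 nM, with a plausible range from 400 nM to 4000 nM.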

Compound 4, half-maximal effective concentration: 3900 nM
Compound 4: the middle estimate sits 3.3-fold (0.51 log units) below what was measured; the range from low to high includes it.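

In this assay, the exchange of hydrogen for bromo lowers the number on the second core as well, with a 3.1-fold lower number from compound 2 to compound 4 (0.50 log units; beyond the scatter), so the direction of the change carries over from one core to the other in the two pairs available. The size of the step does not carry over, and a newcomer should not read one pair's step as a fixed gain from adding this bromine, since the two steps lie further apart than repeated measurements would explain: the same change on two cores in this assay, a 14-fold lower number (1.16 log units; beyond the scatter) from compound 1 to compound 3 and a 3.1-fold lower number (0.50 log units; beyond the scatter) from compound 2 to compound 4, 4.6-fold (0.66 log units) apart, beyond the scatter of two such steps

With just two pairs, this does not show which difference between the cores goes with the larger or smaller step, and it cannot predict whether a third core would follow either of them.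

The compounds shown leave open whether chloro or methyl in place of the new bromo would also lower the number, and by how much on each core. They also leave open whether the step would hold if a methoxy group stood in place of either hydroxy group, or if an amine or a carboxylic acid were added to the other aromatic ring.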